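Sulfonyl substituent swap at the ring nitrogen: compound 3 to compound 4

The source may hold more compounds than are shown below. What is called first, only, known or untested is meant among the compounds shown, and "the series" means these compounds.

Compound 1 `O=C(C1CC12CCC2)N1CCc2nc(C#Cc3ccccc3)sc2C1` in an assay on HEK293 cells for positive allosteric modulation of metabotropic glutamate receptor 5 (Homo sapiens), read by FLIPR, with a stated time of 1 h (on this read-out higher numbers stand for an effect only at larger amounts of compound and lower numbers for an effect already at smaller amounts), gives 3.9 nM.
Compound 2 `O=C(C1CCCCO1)N1CCc2nc(C#Cc3ccccc3)sc2C1` in this assay gives 320 nM.
Compound 3 `CC(C)S(=O)(=O)N1CCc2nc(C#Cc3ccccc3)sc2C1` in this assay gives only a limit, > 10000 nM.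

Compound 1 sits at the lowest number of the three. Exchanging its acyl group for (oxan-2-yl)carbonyl gives an 82-fold higher number from compound 1 to compound 2 (1.91 log units; beyond the scatter), and for isopropylsulfonyl gives an at least 2500-fold higher number from compound 1 to compound 3 (3.40 log units; beyond the scatter). Between the two six-atom replacements the step is an at least 31-fold higher number from compound 2 to compound 3 (1.49 log units; beyond the scatter). For compound 3 no number is resolved; it stands at the limit of this assay (the limit of > 10000 nM in this assay, at which 1 of the 3 values shown sits).

Compound 4 `O=S(=O)(C1CC1)N1CCc2nc(C#Cc3ccccc3)sc2C1` differs from compound 3 by cyclopropyl in place of isopropyl on a sulfonyl sulfur. Within the data shown here, no measured step touches a substituent on the sulfonyl sulfur; the three known steps all exchange the whole group on the ring nitrogen, and both steps ending in the sulfonamide are large and toward higher numbers. The step from compound 3 to compound 4 is therefore expected to be small, a step that the limit leaves unreadable from compound 3 to compound 4. Compound 4 is expected to remain near or at the limit, estimated at 15000 nM with a range of 4000 nM to 50000 nM.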

Compound 4, half-maximal effective concentration: > 10000 nM
Compound 4: no number, only a limit; the forecaster's own chance of this, stated with the estimate: 80%; the middle value lies beyond the limit too.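

In this assay compound 4 gives only a limit, > 10000 nM. Cyclopropyl in place of isopropyl on a sulfonyl sulfur therefore yields no readable value, and the step from compound 3 to compound 4 cannot be read: the limit of > 10000 nM in this assay, at which 2 of the 4 values shown sit. Against the two amides, cyclopropylsulfonyl gives an at least 31-fold higher number from compound 2 to compound 4 (1.49 log units; beyond the scatter) and an at least 2500-fold higher number from compound 1 to compound 4 (3.40 log units; beyond the scatter), so the large steps seen with isopropylsulfonyl now hold for a second sulfonyl group, with no sulfonamide among those shown going against them.

As far as these compounds go, how far either sulfonamide lies beyond the limit stays unknown, and so does whether the two differ at all. Also open, from the compounds shown here alone, is whether a phenyl group or a longer chain on the sulfonyl sulfur would give a readable value.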